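A few compounds are considered here, and "the series" means these few. Any claim that something is new, unique, unknown or untested is made for them only; others in the source may bear on it.

Working notes on the series.

Compound 1 `c1ccc(-c2ccncc2)c(OCC2=NCCN2)c1` is measured in a functional assay for activation of Alpha-1A adrenergic receptor (Homo sapiens), read by calcium flux (a higher number here means that more compound is needed for the effect, a lower number that less compound is needed), only as a limit of that assay, < 100000 nM, and no number is known for it. Compound 2 `Cc1cccnc1-c1ccccc1OCC1=NCCN1` likewise gives only a limit in this assay, < 100000 nM. Compound 3 `Cc1cccc(-c2ccccc2OCC2=NCCN2)n1` gives 126 nM in this assay. Thus compound 1 stands at the limit, alongside (the limit of < 100000 nM in this assay, at which 2 of the 3 values shown sit), and only compound 3 carries a number; where compound 1 sits against compound 3 cannot be told from a limit.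

Compound 4 `c1csc(-c2ccccc2OCC2=NCCN2)c1` has not yet been measured in this assay. It differs from compound 1 in one place: thiophen-2-yl in place of pyridin-4-yl on an aromatic carbon. For the measured compounds named here, no measured step of this kind exists, so the size of the move from compound 1 to compound 4 rests on the change alone; with compound 1 known only as a limit, a direction cannot be read from the measured values either.

Compound 4 is expected to give about 800 nM in this assay, within 60 nM to 10000 nM, which is meant as a step that the limit leaves unreadable from compound 1 to compound 4 in the estimate.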

Compound 4, half-maximal effective concentration: 1 nM
The estimate for compound 4 lay 800-fold (2.90 log units) above the measured number; measured number outside the range, below it.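

No step can be read from compound 1 to compound 4, as compound 1 stands only as a limit in this assay: the limit of < 100000 nM in this assay, at which 2 of the 4 values shown sit.

The compounds shown leave open how far thiophen-2-yl in place of pyridin-4-yl moves the value when both partners carry a number.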